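The source may hold more compounds than are shown below. What is called first, only, known or untested is meant among the compounds shown, and "the series" means these compounds.

Within the data shown here, compound 2 `CCN(CC)CCCC(C)Nc1nc(COc2ccccc2)nc2ccccc12` gives the only plain number in an assay on isolated protein for inhibition of C-C chemokine receptor type 4 (Homo sapiens) (on this read-out lower numbers stand for stronger inhibition and higher numbers for weaker inhibition), namely 2000 nM. Compound 1 `CCN(CC)CCCC(C)Nc1nc(CCCc2ccccc2)nc2ccccc12` reaches only the limit of this assay at > 10000 nM. Among the measured compounds shown here, the single measured step, an at least 5.0-fold lower number from compound 1 to compound 2 (0.69 log units; beyond the scatter), shows that exchanging the group on the shared core can shift the number. Compound 3 `CCN(CC)CCCC(C)Nc1nc(C(=O)Nc2ccccc2)nc2ccccc12` differs from compound 2 by phenylcarbamoyl in place of phenoxymethyl on an aromatic carbon. For the measured compounds named here, no measured step covers this particular exchange, so the expectation rests on compound 2 alone. Compound 3 is therefore estimated near 3000 nM, within a range from 700 nM to 15000 nM. That estimate amounts to a 1.5-fold higher number from compound 2 to compound 3 (0.18 log units; within the scatter), expected to stay within the scatter.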

Compound 3, half-maximal inhibitory concentration: > 10000 nM
Compound 3 gave a limit, no number; the forecaster's own chance of this, stated with the estimate: 30%; middle value at least 3.3-fold (0.52 log units) from the limit.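

Exchanging phenoxymethyl for phenylcarbamoyl on the aromatic carbon between two ring nitrogen atoms gives an at least 5.0-fold higher number from compound 2 to compound 3 (0.69 log units; beyond the scatter), although both groups carry the same six-membered aromatic ring. The atoms joining that ring to the shared core therefore count here, not the ring alone, and among the compounds shown only the phenoxymethyl of compound 2 gives a plain number. The step between compound 1 and compound 3 cannot be read because both values are limits, not numbers: the limit of > 10000 nM in this assay, at which 2 of the 3 values shown sit.

As far as these compounds go, it remains open whether a phenylaminomethyl group, with an amine nitrogen in place of the ether oxygen, would behave like phenoxymethyl. A longer chain ending in a phenoxy group is also untested among these compounds.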